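This account rests on a few compounds, and the source may have more. Where it says the series, first, only, none or still open, it means among the compounds named here.

Compound 1 `O=C(COc1cccc2ccccc12)N/N=C/c1ccc(O)cc1`: 26.5 ug/mL
Compound 2 `C/C(=N\NC(=O)COc1cccc2ccccc12)c1cccc([N+](=O)[O-])c1`: 12.1 ug/mL
Compound 3 `O=C(COc1cccc2ccccc12)N/N=C/c1ccccc1Br`: 11.4 ug/mL

In an ADME assay on MT4 cells (Homo sapiens) for cytotoxicity, read by MTT assay, with a stated time of 4 days (on this read-out lower numbers stand for higher toxicity in this test and higher numbers for lower toxicity in this test), compound 2 gives 12.1 ug/mL, second of the three numbers. That value lies within the scatter of compound 3 at 11.4 ug/mL, while compound 1 gives 26.5 ug/mL, which stands higher than compound 2 by a gap that lies beyond the scatter.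

The next compound is compound 4 `C/C(=N\NC(=O)COc1cccc2ccccc12)c1ccccc1`, which differs from compound 2 as follows: hydrogen in place of nitro on an aromatic carbon. In short, hydrogen takes the place of nitro on an aromatic carbon, and the 3-nitrophenyl becomes a phenyl.

Among the measured compounds shown here, no measured step removes a nitro group, so the evidence is indirect. For the measured compounds named here, the only step available, a 2.3-fold lower number from compound 1 to compound 3 (0.37 log units; beyond the scatter), exchanges different groups and is modest, only just beyond the scatter. On the strength of that step from compound 1, no large change is expected here, and no firm direction can be assigned. The expected step is a 1.2-fold higher number from compound 2 to compound 4 (0.09 log units; within the scatter), which stays within the scatter. The estimated value for compound 4 is 15 ug/mL, with an expected range from 6 ug/mL to 40 ug/mL.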

Compound 4, half-maximal cytotoxic concentration: 105 ug/mL
The estimate for compound 4 lay 7.0-fold (0.85 log units) below the measured number; measured number above the stated range.
By their numbers in this assay, from the lowest: compounds 3 and 2 (each within the scatter of the next); then compound 1; then compound 4.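

In this assay, replacing nitro with hydrogen on the aromatic carbon gives an 8.7-fold higher number from compound 2 to compound 4 (0.94 log units; beyond the scatter), so the 3-nitrophenyl and the phenyl are not interchangeable on this core, and the phenyl stands on the side of lower toxicity in this test. The earlier compounds shown here offered only a 2.3-fold lower number from compound 1 to compound 3 (0.37 log units; beyond the scatter), which exchanges different groups and so gave no reading of this place. No measured property bears on this result.

From the compounds shown here alone, it remains open whether the step is particular to nitro, or whether an amine, a nitrile or a methoxy group at the same place would also keep the number near that of compound 2. Also open, going by these compounds, is whether the same change gives a similar step on the core of compound 1, which has hydrogen instead of methyl on the carbon with a double bond to nitrogen.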